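The source may hold more compounds than are shown below. What is called first, only, known or untested is meant among the compounds shown, and "the series" means these compounds.

Compound 2 `CCOC(=O)c1c(-c2ccccc2O)n(-c2ccc(C(=O)NNC(=O)CO[N+](=O)[O-])cc2)[nH]c1=O` gives 70.8 ug/mL in a functional assay on aorta (Rattus norvegicus, strain Wistar) for inhibition; on this read-out higher numbers stand for an effect only at larger amounts of compound and lower numbers for an effect already at smaller amounts. For the measured compounds named here, its number is the larger of the two measured so far, though the gap to compound 1 `CCOC(=O)c1c(-c2ccccc2OC)n(-c2ccc(C(=O)NNC(=O)CO[N+](=O)[O-])cc2)[nH]c1=O`, which gives 63.1 ug/mL, lies within the scatter. Going by the values given here, the only measured step, a 1.1-fold higher number from compound 1 to compound 2 (0.05 log units; within the scatter), concerned hydrogen in place of methyl on an oxygen on an aromatic ring. Compound 3 `CCOC(=O)c1c(-c2ccc(Cl)cc2)n(-c2ccc(C(=O)NNC(=O)CO[N+](=O)[O-])cc2)[nH]c1=O` carries 4-chlorophenyl in place of 2-hydroxyphenyl on an aromatic carbon. Among the compounds with values here, no measured step exchanges this whole ring, so the earlier step bears only loosely on it. The step from compound 2 to compound 3 is expected to be small, a 1.1-fold lower number from compound 2 to compound 3 (0.04 log units; within the scatter). Compound 3 is estimated at 65 ug/mL, ranging from 30 ug/mL to 140 ug/mL.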

Compound 3, half-maximal effective concentration: 50.2 ug/mL
The estimate for compound 3 lay 1.3-fold (0.11 log units) above the measured number; measured number inside the range.
By their numbers in this assay, from the lowest: compounds 3, 1 and 2 (each within the scatter of the next).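

Replacing the whole ring on this aromatic carbon with 4-chlorophenyl gives a 1.4-fold lower number from compound 2 to compound 3 (0.15 log units; within the scatter) and a 1.3-fold lower number from compound 1 to compound 3 (0.10 log units; within the scatter), so even this larger exchange stays within the scatter. The entering ring has no hydrogen-bond donor, yet the 2-hydroxyphenyl, 2-methoxyphenyl and 4-chlorophenyl compounds cannot be told apart here. No measured evidence accounts for these small steps.

Still open, as far as these compounds go, is whether a ring carrying an amine or a carboxylic acid would also stay within the scatter. From the compounds shown here alone, a longer chain in place of the ring remains equally open.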